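The source may report more compounds than this note shows. Statements on the series, on what has been measured and on what is new or still open speak of the compounds shown alone.

The three measured compounds, each tested in a functional assay on HT-29 cells (Homo sapiens) for antiproliferative activity, read by sulforhodamine B assay, with a stated time of 48 h; on this read-out lower numbers stand for stronger inhibition and higher numbers for weaker inhibition:

compound 1 `O=C1NCCN1c1ccc(S(=O)(=O)Nc2ccc3[nH]ccc3c2)cc1`, which gives 130 nM
compound 2 `Cc1ccc(NS(=O)(=O)c2ccc(N3CCNC3=O)cc2)cc1C`, which gives 230 nM
compound 3 `COc1ccc(NS(=O)(=O)c2ccc(N3CCNC3=O)cc2)cc1OC`, which gives 520 nM

Among these three numbers compound 2 holds the second highest. Its nearest neighbour is compound 1, whose number is lower by an amount that stays within the usual scatter of this kind of measurement, so the two cannot be ordered with confidence. Its furthest neighbour is compound 3, whose number is higher by a margin that lies beyond the scatter.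

The next compound, compound 4 `O=C1NCCN1c1ccc(S(=O)(=O)Nc2cccc(Cl)c2)cc1`, has not yet been measured in this assay. It differs from compound 2 at one place: 3-chlorophenyl in place of 3,4-dimethylphenyl on a sulfonamide nitrogen

Within the data shown here, the three measured compounds share a common core and differ only in the group on the sulfonamide nitrogen, and no single-point step between any two of them is available as a guide. Nothing in the three numbers points to a large shift in either direction for this exchange, so the step expected in this assay from compound 2 to compound 4 is none beyond the scatter, with a wide range to reflect the uncertainty. Compound 4 is therefore estimated at 260 nM, within a range from 100 nM to 700 nM, an expected step of a 1.1-fold higher number from compound 2 to compound 4 (0.05 log units; within the scatter).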

Compound 4, half-maximal inhibitory concentration: 55 nM
The estimate for compound 4 lay 4.7-fold (0.67 log units) above the measured number; measured number outside the range, below it.
By their numbers in this assay, from the lowest: compound 4; then compounds 1 and 2 (each within the scatter of the next); then compound 3.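

In this assay, putting 3-chlorophenyl in place of 3,4-dimethylphenyl on a sulfonamide nitrogen gives a 4.2-fold lower number from compound 2 to compound 4 (0.62 log units; beyond the scatter). Among these compounds, this is the only single-place step available among the compounds, and it shows that a change in this group alone, with the rest of the shared core held constant, can move the number beyond the scatter, which the earlier compounds could not show because no two of them formed such a pair. No measurement accompanies the result that would account for the size or direction of this step.

Going by these compounds, the exchange removes both methyl groups and brings in a chlorine in a single move, so it remains open whether the shift follows the loss of the methyl groups, the entry of the chlorine or the two together, a question that a 3-methylphenyl or a 4-chlorophenyl group on the same nitrogen would help to separate. Also open, on these data alone, is how this position responds to other kinds of substituent on the ring, such as a nitrile, an amine or a carboxylic acid.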